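This account rests on a few compounds, and the source may have more. Where it says the series, first, only, none or still open, it means among the compounds named here.

Compound 1 `O=C(Nc1ccccc1Cl)N1CCC(c2nc(-c3ccc4ccccc4n3)no2)CC1` carries a 2-chlorophenyl group on an amide-type nitrogen. In a functional assay on Shh Light II cells (Mus musculus) for inhibition, read by a luciferase reporter (a higher number here means a weaker inhibitor, a lower number a stronger inhibitor), compound 1 gives 510 nM. For the measured compounds named here, only one other compound has been measured: compound 2 `O=C(NC1CCS(=O)(=O)CC1)N1CCC(c2nc(-c3ccc4ccccc4n3)no2)CC1`, in which that aryl group is swapped for a saturated ring. In this assay compound 2 gives 360 nM. Going by the values given here, the single measured step, a 1.4-fold lower number from compound 1 to compound 2 (0.15 log units; within the scatter), tells how compound 1 stands: its number and that of compound 2 cannot be told apart, so neither can be called stronger or weaker.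

The next compound, compound 3 `O=C(NC1CCOCC1)N1CCC(c2nc(-c3ccc4ccccc4n3)no2)CC1`, differs from compound 1 as follows: oxan-4-yl in place of 2-chlorophenyl on an amide-type nitrogen. This is the same kind of move as in the step to compound 2, an aromatic ring on that nitrogen giving way to a six-membered saturated ring with hetero atoms, and the step from compound 1 to compound 2 a 1.4-fold lower number from compound 1 to compound 2 (0.15 log units; within the scatter) stayed within the scatter. On that basis the step from compound 1 to compound 3 is expected to be small, a 1.2-fold lower number from compound 1 to compound 3 (0.08 log units; within the scatter), with no clear direction beyond the scatter. For compound 3 the expected value in this assay is 420 nM, within a range from 200 nM to 900 nM.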

Compound 3, half-maximal inhibitory concentration: 480 nM
The estimate for compound 3 lay 1.1-fold (0.06 log units) below the measured number, and the stated range covers the measured number.
By their numbers in this assay, from the lowest: compounds 2, 3 and 1 (each within the scatter of the next).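

In this assay the group on the amide-type nitrogen now comes in three forms, and the step to oxan-4-yl (a 1.1-fold lower number from compound 1 to compound 3 (0.03 log units; within the scatter)) stays inside the scatter, as the step to compound 2 did. For the compounds shown here, the second new step (a 1.3-fold higher number from compound 2 to compound 3 (0.12 log units; within the scatter)) adds a comparison the earlier compounds could not give: two saturated six-membered rings with different hetero atom groups also cannot be told apart, so none of 2-chlorophenyl, 1,1-dioxothian-4-yl and oxan-4-yl can be called stronger or weaker at this position. So far, this place tolerates an aromatic ring and saturated rings alike, but no measurement shown here speaks to the reason.

On these data alone, all three groups are six-membered rings with no net charge, so it remains open whether an open-chain group such as a short alkyl chain, or a ring carrying an amine or a carboxylic acid, would move the number beyond the scatter. All three compounds also share the same core, which leaves open how far a change elsewhere in that core would shift the number.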